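Aryl swap at the shared core: compound 3 to compound 4

This account rests on a few compounds, and the source may have more. Where it says the series, first, only, none or still open, it means among the compounds named here.

Compound 1 `COc1ccc(CN2C(=O)C(=O)c3cc(-c4ccc(OC)cc4)ccc32)cc1` is the anchor of the set; in a functional assay on HepG2 cells (Homo sapiens) for antiproliferative activity, read by MTT assay, with a stated time of 48 h (a higher number here means a weaker inhibitor, a lower number a stronger inhibitor), compound 1 gives 50 nM. Compound 2 `COc1ccc(CN2C(=O)C(=O)c3cc(-c4ccc(OC)c(OC)c4)ccc32)cc1` carries a further methoxy on the pendant ring. In this assay compound 2 reaches only a limit of the assay, > 10000 nM. Compound 3 `COc1ccc(CN2C(=O)C(=O)c3cc(-c4ccc(OC(C)C)cc4)ccc32)cc1` has isopropoxy instead of methoxy on that ring. In this assay compound 3 likewise sits at a limit, > 10000 nM. The step of an at least 200-fold higher number from compound 1 to compound 2 (2.30 log units; beyond the scatter) and the step of an at least 200-fold higher number from compound 1 to compound 3 (2.30 log units; beyond the scatter) are both large, so compound 3 stands at the weak end of the numbers shown. Between compound 2 and compound 3 the step that the two limits leave unreadable from compound 2 to compound 3, because of the limit of > 10000 nM in this assay, at which 2 of the 3 values shown sit.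

Compound 4 `COc1ccc(CN2C(=O)C(=O)c3cc(-c4ccc5ccccc5c4)ccc32)cc1` differs from compound 3 by naphthalen-2-yl in place of 4-isopropoxyphenyl on an aromatic carbon. For the measured compounds named here, no measured step touches a naphthalen-2-yl group; the two steps that bear on the pendant ring, an at least 200-fold higher number from compound 1 to compound 2 (2.30 log units; beyond the scatter) and an at least 200-fold higher number from compound 1 to compound 3 (2.30 log units; beyond the scatter), show that either change made there drove the number to the limit. The incoming group keeps the same heavy-atom count as 4-isopropoxyphenyl and drops its hydrogen-bond acceptor. An expectation of little change, an at least 1.6-fold lower number from compound 3 to compound 4 (0.22 log units; that floor lies within the scatter), is therefore held, with a fair chance that compound 4 also returns only a limit. Compound 4 is estimated at 6000 nM, in the range 200 nM to 10000 nM.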

Compound 4, half-maximal inhibitory concentration: > 10000 nM
Compound 4 gave a limit, no number; the forecaster's own chance of this, stated with the estimate: 55%; middle value at least 1.6-fold (0.22 log units) from the limit.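

Replacing 4-methoxyphenyl with naphthalen-2-yl gives an at least 200-fold higher number from compound 1 to compound 4 (2.30 log units; beyond the scatter) in this assay, so the loss at this aromatic carbon is not confined to adding a methoxy or to lengthening the alkoxy group. The pendant group here has two six-membered aromatic rings of carbon only and no hydrogen-bond acceptor, yet the outcome matches that of the two alkoxy-bearing changes, and among the four compounds only compound 1 gives a number. The steps from compound 2 to compound 4 and from compound 3 to compound 4 cannot be read, and no order can be given among compound 2, compound 3 and compound 4, because all three values are limits: the limit of > 10000 nM in this assay, at which 3 of the 4 values shown sit.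

From the compounds shown here alone, it remains open whether a plain phenyl, a 4-hydroxyphenyl or a 4-aminophenyl on this aromatic carbon would return a number, which would show how narrowly the result depends on the 4-methoxyphenyl group. Also open, going by these compounds, is whether the number of compound 1 survives when its 4-methoxybenzyl group gives way to a plain benzyl.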